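Carbamoyl at the benzyl ring of an indazole-pyridinone inhibitor

The source may report more compounds than this note shows. Statements on the series, on what has been measured and on what is new or still open speak of the compounds shown alone.

Compound 2 `O=c1ccc(-c2ccc3cn[nH]c3c2)cn1Cc1ccccc1` and compound 1 `O=c1ccc(-c2ccc3cn[nH]c3c2)cn1Cc1ccccc1C(F)(F)F` share one core and differ only at the benzyl ring. In an assay for inhibition of MAP kinase-interacting serine/threonine-protein kinase 2 (Homo sapiens), read by luminescence and ADP-Glo, with a stated time of 2 h (a higher number here means a weaker inhibitor, a lower number a stronger inhibitor), compound 1 gives 100 nM, and compound 2 gives 75 nM; the step of a 1.3-fold lower number from compound 1 to compound 2 (0.12 log units; within the scatter) leaves the two within the scatter of each other. Compound 3 `NC(=O)c1ccccc1Cn1cc(-c2ccc3cn[nH]c3c2)ccc1=O` carries the change (carbamoyl in place of hydrogen on an aromatic carbon). For the measured compounds named here, only that one step bears on the new change, and it was small, so no movement beyond the scatter is expected. The estimate for compound 3 is 60 nM, between 20 nM and 200 nM, a step of a 1.3-fold lower number from compound 2 to compound 3 (0.10 log units; within the scatter).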

Compound 3, half-maximal inhibitory concentration: 340 nM
Compound 3: middle estimate off by 5.7-fold (0.75 log units), on the low side; the measured number lies above the stated range.
By their numbers in this assay, from the lowest: compounds 2 and 1 (each within the scatter of the next); then compound 3.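

Trifluoromethyl and hydrogen had left the number in this assay within the scatter, so this position on the benzyl ring had seemed indifferent to its substituent. Carbamoyl is the first group here to move the number beyond the scatter, with a 4.5-fold higher number from compound 2 to compound 3 (0.66 log units; beyond the scatter) and a 3.4-fold higher number from compound 1 to compound 3 (0.53 log units; beyond the scatter), so the position does discriminate between groups and this change weakens inhibition against both earlier compounds. Nothing available accounts for this loss. Still open, on these data alone, is whether the loss belongs to carbamoyl as a whole or to part of it. A nitrile, a carboxylic acid or an amine at the same place would help to separate these.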